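This account rests on a few compounds, and the source may have more. Where it says the series, first, only, none or still open, it means among the compounds named here.

Working notes on the series. In a functional assay on COLO 205 cells (Homo sapiens) for inhibition, read by sulforhodamine B assay, with a stated time of 48 h, tested at 50 uM (on this read-out higher numbers stand for more inhibition of growth at the one concentration tested and lower numbers for less inhibition of growth), compound 1 (`COc1cc(/C=C/C(=O)/C=C/c2cccc3ccccc23)ccc1OCc1cn(CCOc2cc(=O)oc3ccccc23)nn1`) reads 85% and compound 3 (`COc1cccc(/C=C/C(=O)/C=C/c2ccc(OCc3cn(CCCCCOc4cc(=O)oc5ccccc45)nn3)c(OC)c2)c1`) reads 34% on this scale. Compound 2 (`COc1ccc(/C=C/C(=O)/C=C/c2ccc(OCc3cn(CCCCOc4cc(=O)oc5ccccc45)nn3)c(OC)c2)cc1OC`) reads 53% and stands second highest of the three, with its gaps to both others beyond the usual scatter. Among the measured compounds shown here, these three compounds differ from one another in more than one place, so no measured step isolates a single change.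

Compound 4 (`COc1cc(/C=C/C(=O)/C=C/c2ccccc2)ccc1OCc1cn(CCCCOc2cc(=O)oc3ccccc23)nn1`) departs from compound 2 in one place (phenyl in place of 3,4-dimethoxyphenyl on a double-bonded chain carbon bound to a double-bonded chain carbon) with phenyl in place of 3,4-dimethoxyphenyl on a double-bonded chain carbon bound to a double-bonded chain carbon. For the measured compounds named here, the series holds no measured example of this change, so no direction is favoured in this assay and no step beyond the scatter is expected. The estimated step is small (a number 2 percentage points higher from compound 2 to compound 4 (within the scatter)) and stays within the scatter. The three measured values lie far apart, so the range is kept wide. The estimate for compound 4 is 55% with an expected range from 35% to 75% in this read-out.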

Compound 4, percent growth inhibition at one concentration: 31%
Compound 4: middle estimate off by 24 percentage points, on the high side; measured number outside the range, below it.
By their numbers in this assay, from the lowest: compounds 4 and 3 (each within the scatter of the next); then compound 2; then compound 1.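

In this assay, among the compounds shown here, phenyl in place of 3,4-dimethoxyphenyl on a double-bonded chain carbon bound to a double-bonded chain carbon gives a number 22 percentage points lower from compound 2 to compound 4 (beyond the scatter), the first step that isolates a single change. This position is therefore not silent: the aryl group held there alters growth inhibition at the one concentration tested, and here 3,4-dimethoxyphenyl gives the higher reading. No measurement shown accounts for the size or direction of this step.

Going by these compounds, compound 1 and compound 3 differ from compound 2 and compound 4 in more than one place, so their steps cannot be read, and it stays open whether the step holds with the other aryl groups and linkers. Also open, on these data alone, is how a single methoxy group, a chlorine or an amine on the phenyl ring would read at this position.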